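The source may hold more compounds than are shown below. What is called first, only, known or untested is meant among the compounds shown, and "the series" means these compounds.

The measured compounds:

Compound 1, `CCOC(=O)c1c(-c2cccc(Oc3ccccc3)c2)[nH]c2cc(OC)ccc2c1=O`. In an ADME assay on BJ cells (Homo sapiens) for cytotoxicity, read by luminescence, with a stated time of 72 h (a lower number here means that less compound is needed, a higher number that more compound is needed for the effect), compound 1 gives > 21500 nM, which is a limit of the assay and not a number.
Compound 2, `CCOC(=O)c1c(-c2cccc(OC(F)(F)F)c2)[nH]c2cc(OC)ccc2c1=O`. In this assay compound 2 gives > 21500 nM, again a limit of the assay.
Compound 3, `CCOC(=O)c1c(-c2cccc(Oc3ccccc3)c2)[nH]c2cc(OC)c(F)cc2c1=O`. In this assay compound 3 gives > 21500 nM, once more a limit of the assay.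

The three measured compounds share one core and differ from one another in two places. From compound 1 to compound 2 the change is trifluoromethyl in place of phenyl on an oxygen on an aromatic ring. The step it made in this assay is a step that the two limits leave unreadable from compound 1 to compound 2. The cores of compound 1 and compound 3 differ by fluoro in place of hydrogen on an aromatic carbon, and the step there is a step that the two limits leave unreadable from compound 1 to compound 3. Both steps are unreadable for the same reason, namely (the limit of > 21500 nM in this assay, at which 3 of the 3 values shown sit), so no ordering among the three can be drawn from these values.

Compound 4, `CCOC(=O)c1c(-c2cccc(OC(F)(F)F)c2)[nH]c2cc(OC)c(F)cc2c1=O`, has not yet been measured in this assay. Among the measured compounds shown here, it differs from compound 3 by trifluoromethyl in place of phenyl on an oxygen on an aromatic ring, which is the same change, at the same place, as the one made from compound 1 to compound 2. For the measured compounds named here, since that earlier step reads a step that the two limits leave unreadable from compound 1 to compound 2 and every value so far sits at the limit of > 21500 nM in this assay, at which 3 of the 3 values shown sit, compound 4 is expected to stay at or beyond the limit as well. The step from compound 3 to compound 4 is therefore expected to be a step that the limit leaves unreadable from compound 3 to compound 4. Compound 4 is estimated at about 30000 nM, with a range from 21500 nM to 100000 nM, and most likely the assay will again report only a limit.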

Compound 4, half-maximal effective concentration: > 21500 nM
Compound 4 ended at the assay's limit; the forecaster's own chance of this, stated with the estimate: 90%; the middle value lies beyond the limit too.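

Compound 4 adds no readable step: its comparisons with compound 3 and with compound 2 both remain unreadable, because all four compounds stop at the same limit, which is not a number: the limit of > 21500 nM in this assay, at which 4 of the 4 values shown sit.

The compounds shown leave open how far each one lies beyond that limit, and whether any change to the shared core would give a readable value in this assay.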